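Compound 3 in a series held at the assay limit

This account rests on a few compounds, and the source may have more. Where it says the series, first, only, none or still open, it means among the compounds named here.

compound 1 `Cn1c(=O)[nH]c2c(nc(Br)n2C2O[C@H](CO)[C@@H](O)[C@H]2O)c1=N`: > 100 mg/kg
compound 2 `Cn1c(=O)[nH]c2c(nc(NN)n2C2O[C@H](CO)[C@@H](O)[C@H]2O)c1=N`: > 100 mg/kg

In a functional assay on the whole organism with Mus musculus as the target (on this read-out higher numbers stand for an effect only at larger amounts of compound and lower numbers for an effect already at smaller amounts), compound 2 is known only as a limit, > 100 mg/kg. Among the compounds with values here, the same holds for the whole series so far: the limit of > 100 mg/kg in this assay, at which 2 of the 2 values shown sit. Compound 3 `Cn1c(=O)[nH]c2c(nc(N)n2C2O[C@H](CO)[C@@H](O)[C@H]2O)c1=N` carries hydrogen in place of amino on a nitrogen on an aromatic ring. Within the data shown here, the only measured step is a step that the two limits leave unreadable from compound 1 to compound 2, so it offers no size to carry over. A step of a number no higher from compound 2 to compound 3 (the limit leaves the size open) is expected, though its direction remains uncertain, and another limit is the likeliest report. For compound 3 the estimate is 100 mg/kg, with an expected range of 30 mg/kg to 300 mg/kg.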

Compound 3, dose for half-maximal effect: > 100 mg/kg
Compound 3 ended at the assay's limit; the forecaster's own chance of this, stated with the estimate: 70%; the middle value lies on the limit itself.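

Compound 3 gives > 100 mg/kg in this assay, a limit of the assay. Within the data shown here, no step among compound 1, compound 2 and compound 3 can be read. The compounds shown leave open how far these three differ from one another.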